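The compounds below may be only part of what the source reports. "The series", "measured", "known", "first", "only" and "open" are said of these compounds alone.

Compound 2, `COc1cccc(-c2cc(-c3ccccc3)c3c(N)n[nH]c3n2)c1`, and compound 1, `Nc1n[nH]c2nc(-c3ccccc3)cc(-c3ccc(F)cc3)c12`, share a core that differs only in the group carried on one phenyl ring. In an assay on cells for inhibition of MAP kinase-interacting serine/threonine-protein kinase 2 (Homo sapiens), read by scintillation counting, radiometric assay and 33P incorporation, with a stated time of 60 min, in the presence of a further agent that is not named here (a higher number here means a weaker inhibitor, a lower number a stronger inhibitor), compound 1 gives 4100 nM, and in this assay compound 2 gives 22000 nM, the higher of the two numbers, with compound 1 the nearest neighbour at a lower number, a gap that lies beyond the scatter. Compound 3, `Nc1n[nH]c2nc(-c3ccccc3)cc(-c3ccccc3)c12`, has not been measured. It differs from compound 2 by hydrogen in place of methoxy on an aromatic carbon, so that the ring bearing the methoxy becomes a plain phenyl. Going by the values given here, no step between measured compounds covers this exact change, so the expectation rests on the two values alone: the estimate is that removing the methoxy moves compound 3 toward the lower number of compound 1, giving a step of a 3.7-fold lower number from compound 2 to compound 3 (0.56 log units; beyond the scatter) toward stronger inhibition. Compound 3 is therefore expected to give 6000 nM, with a range from 2000 nM to 18000 nM.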

Compound 3, half-maximal inhibitory concentration: 9400 nM
Estimate against measurement, compound 3: 1.6-fold (0.19 log units) below; the range from low to high includes it.
By their numbers in this assay, from the lowest: compound 1; then compound 3; then compound 2.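

With the plain phenyl of compound 3 as a reference, the 3-methoxyphenyl group can now be read as a change on its own: in this assay, hydrogen in place of methoxy gives a 2.3-fold lower number from compound 2 to compound 3 (0.37 log units; beyond the scatter), a modest gain in inhibition. Hydrogen in place of fluoro works the other way and gives a 2.3-fold higher number from compound 1 to compound 3 (0.36 log units; beyond the scatter), also modest, so among these three compounds a substituent on this ring can move the number in either direction from that of the plain phenyl. Nothing shown here gives a reason for either step. As far as these compounds go, it remains open whether an amine, a hydroxyl or a carboxylic acid on this ring would lower the number further than fluoro does. From the compounds shown here alone, it is also open whether a chlorine would follow fluoro or methoxy.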